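The compounds below may be only part of what the source reports. "The series", "measured", "known", "first", "only" and "open" are said of these compounds alone.

Of the compounds shown here, three have been measured.

Compound 1 `CC/C=C\Cn1c(Cc2cc(OC)c(OC)c(OC)c2)nc2c(N)ncnc21`: 64600 nM
Compound 2 `CC#CCCn1c(Cc2cc(OC)c(OC)c(OC)c2)nc2c(N)nc(F)nc21`: 37200 nM
Compound 3 `C=CCCCn1c(Cc2cc(OC)c(OC)c(OC)c2)nc2c(N)nc(F)nc21`: 44700 nM

All three numbers come from a functional assay on MCF7 cells (Homo sapiens) for antiproliferative activity; a lower number here means a stronger inhibitor, a higher number a weaker inhibitor. Compound 1 gives 64600 nM in this assay, and its gaps to compound 3 and to compound 2 both lie within the usual scatter, so the three compounds cannot be told apart on these numbers. For the measured compounds named here, the one step among them that changes a single place, a 1.2-fold higher number from compound 2 to compound 3 (0.08 log units; within the scatter), is likewise within the scatter.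

Compound 4 `COc1cc(Cc2nc3c(N)ncnc3n2CC(OC)OC)cc(OC)c1OC` has not been measured. Compared with compound 1 the change is dimethoxymethyl in place of but-1-en-1-yl on a saturated chain carbon bound to an aromatic nitrogen. Going by the values given here, the only measured step, from compound 2 to compound 3, also alters the chain on the aromatic nitrogen and moved the number by very little, but it exchanges one unsaturated chain for another and says nothing directly about dimethoxymethyl. Among the compounds with values here, with no closer precedent, the step is expected to stay near the scatter, a 1.1-fold lower number from compound 1 to compound 4 (0.03 log units; within the scatter). Compound 4 is therefore estimated at 60000 nM in this assay, with a range from 20000 nM to 180000 nM.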

Compound 4, half-maximal inhibitory concentration: 72400 nM
Compound 4: the middle estimate sits 1.2-fold (0.08 log units) below what was measured; the range from low to high includes it.
By their numbers in this assay, from the lowest: compounds 2, 3, 1 and 4 (each within the scatter of the next).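

In this assay, replacing but-1-en-1-yl with dimethoxymethyl gives a 1.1-fold higher number from compound 1 to compound 4 (0.05 log units; within the scatter). The earlier step at this chain only exchanged one unsaturated hydrocarbon group for another, whereas this one removes the double bond and brings in a group with 2 hydrogen-bond acceptors, and even so the number cannot be told from that of compound 1. Nothing available explains why the number stays put across this change.

As far as these compounds go, whether an amine or a carboxylic acid at this place on the chain would move the number beyond the scatter remains open. So does whether a longer chain would, since every change seen here leaves the values of the compounds compared within the scatter of each other.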